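Ring amide swap: compound 3 to compound 4

The compounds below may be only part of what the source reports. "The series", "measured", "known", "first", "only" and "open" are said of these compounds alone.

Measured so far in an in vivo functional assay on the whole organism for inhibition, with Rattus norvegicus as the target; on this read-out lower numbers stand for an effect already at smaller amounts and higher numbers for an effect only at larger amounts of compound:
- compound 1 `CCCCc1nc(C)c(CC(=O)N(C)C)c(=O)n1Cc1ccc(-c2ccccc2-c2nnn[nH]2)cc1`: 0.018 mg/kg
- compound 2 `CCCCc1nc(C)c(CC(=O)N2CCCC2)c(=O)n1Cc1ccc(-c2ccccc2-c2nnn[nH]2)cc1`: 0.056 mg/kg
- compound 3 `CCCCc1nc(C)c(CC(=O)N2CCSCC2)c(=O)n1Cc1ccc(-c2ccccc2-c2nnn[nH]2)cc1`: 0.038 mg/kg

Compound 1 has the lowest number of the three. Compound 3, at 0.038 mg/kg, cannot be separated from compound 2, as the step of a 1.5-fold lower number from compound 2 to compound 3 (0.17 log units; within the scatter) shows, but it does stand apart from compound 1, with a 2.1-fold higher number from compound 1 to compound 3 (0.32 log units; beyond the scatter).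

Compound 4 `CCCCc1nc(C)c(CC(=O)N2CCOCC2)c(=O)n1Cc1ccc(-c2ccccc2-c2nnn[nH]2)cc1` is still unmeasured. The change is morpholin-4-yl in place of thiomorpholin-4-yl on a carbonyl carbon.

Among the measured compounds shown here, no measured step makes this exact exchange. For the measured compounds named here, the closest precedent is the exchange of one ring for another, a 1.5-fold lower number from compound 2 to compound 3 (0.17 log units; within the scatter). The modest steps away from the dimethylamino group, a 3.1-fold higher number from compound 1 to compound 2 (0.49 log units; beyond the scatter) and a 2.1-fold higher number from compound 1 to compound 3 (0.32 log units; beyond the scatter), are less close, since the change here is again from ring to ring. In this assay no step beyond the scatter is therefore expected, and no direction is favoured with confidence. The expected step is a 1.2-fold higher number from compound 3 to compound 4 (0.07 log units; within the scatter). For compound 4 the estimated value is 0.045 mg/kg, with an expected range of 0.02 mg/kg to 0.1 mg/kg.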

Compound 4, dose for half-maximal effect: 0.018 mg/kg
Compound 4: the middle estimate sits 2.5-fold (0.40 log units) above what was measured; the measured number lies below the stated range.
By their numbers in this assay, from the lowest: compounds 1 and 4 (each within the scatter of the next); then compounds 3 and 2 (each within the scatter of the next).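

In this assay the ring amides do not form a single level: a 2.1-fold lower number from compound 3 to compound 4 (0.32 log units; beyond the scatter) and a 3.1-fold lower number from compound 2 to compound 4 (0.49 log units; beyond the scatter) show that a ring-to-ring exchange on this carbonyl carbon can move the number beyond the scatter, which the earlier step from pyrrolidin-1-yl to thiomorpholin-4-yl did not show. The rise seen on going from dimethylamino to a ring in compound 2 and compound 3 does not hold for every ring, since no change at the digits printed from compound 1 to compound 4 (within the scatter) leaves the morpholin-4-yl amide level with the open amide. Nothing available explains this difference between the rings.

Still open, from the compounds shown here alone, is how a piperidin-1-yl or a 4-methylpiperazin-1-yl amide would sit against morpholin-4-yl at this position. A single whole-organism read-out also leaves open whether the same exchange would give the same step on another core.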